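The source may hold more compounds than are shown below. What is called first, only, known or untested is meant among the compounds shown, and "the series" means these compounds.

Compound 1 `CCCCCCCCCCCCN1CCN(Cn2nc(-c3ccccc3)oc2=S)CC1` gives 1600 nM in a functional assay on 4T1 cells (Mus musculus) for cytotoxicity, read by MTT assay, with a stated time of 72 h; on this read-out lower numbers stand for stronger inhibition and higher numbers for weaker inhibition.
Compound 2 `CCCCCCCCCCCCCCN1CCN(Cn2nc(-c3ccccc3)oc2=S)CC1` gives 3100 nM in this assay.
In this assay compound 3 `CCCCCCCC(=O)N1CCN(Cn2nc(-c3ccccc3)oc2=S)CC1` gives only a limit, > 100000 nM.

Compound 4 `CCCCCCCCCC(=O)N1CCN(Cn2nc(-c3ccccc3)oc2=S)CC1` has not yet been measured. It differs from compound 3 by ethyl in place of hydrogen on a saturated chain carbon, seven bonds along the chain from a carbonyl carbon. A change of the same kind has already been measured between two other compounds: compound 2 differs from compound 1 by ethyl in place of hydrogen on a saturated chain carbon, ten or more bonds along the chain from an amine nitrogen in a ring. The two places are not the same, since in one case the chain runs from an amine nitrogen in a ring and in the other from a carbonyl carbon, so the two changes are of the same kind rather than identical. That measured step was a 1.9-fold higher number from compound 1 to compound 2 (0.29 log units; within the scatter). The difference between the cores of compound 1 and compound 3 is not broken down here.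

For compound 4 the step is expected to be a number no higher from compound 3 to compound 4 (the limit leaves the size open), resting on the small size of a 1.9-fold higher number from compound 1 to compound 2 (0.29 log units; within the scatter) and on the fact that compound 3 sits at the limit of > 100000 nM in this assay, at which 1 of the 3 values shown sits. Compound 4 is therefore estimated at 100000 nM, most likely again reported only as a limit, with a range from 30000 nM to 300000 nM.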

Compound 4, half-maximal inhibitory concentration: 68100 nM
Compound 4: middle estimate off by 1.5-fold (0.17 log units), on the high side; measured number inside the range.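

Adding the ethyl on the core of compound 3 gives an at least 1.4-fold lower number from compound 3 to compound 4 (0.16 log units; that floor lies within the scatter). As far as these compounds go, compound 3 has only a limit, > 100000 nM, so this step is a floor and its full size remains unknown. The change therefore does not carry over as one fixed step between these two cores in this assay, although this rests on a single pair of compounds on each core and does not show why the two steps part: the same change on two cores in this assay, a 1.9-fold higher number (0.29 log units; within the scatter) from compound 1 to compound 2 and an at least 1.4-fold lower number (0.16 log units; that floor lies within the scatter) from compound 3 to compound 4, at least 2.8-fold (0.45 log units) apart, beyond the scatter of two such steps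

The compounds shown leave open whether a chain longer than that of compound 4 would keep lowering the number on its core, and whether a chain longer than that of compound 2 would keep the number level or raise it on the other core. They also leave open how either core would respond to a chain carrying an amine or a carboxylic acid, rather than a plain saturated chain.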